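The compounds below may be only part of what the source reports. "The series", "measured", "known", "first", "only" and "open" are said of these compounds alone.

Measured compounds:
- compound 1 `O=[N+]([O-])c1ccc(CSc2nnc(-c3ccc4c(c3)OCCO4)n2-c2ccccc2)cc1` with 13800 nM
- compound 2 `Cc1ccc(CSc2nnc(-c3ccc4c(c3)OCCO4)n2-c2ccccc2)cc1` with 56800 nM
- compound 3 `Fc1ccc(CSc2nnc(-c3ccc4c(c3)OCCO4)n2-c2ccccc2)cc1` with 1020 nM

In a functional assay on HepG2 cells (Homo sapiens) for antiproliferative activity, read by MTT assay, with a stated time of 24 h (on this read-out higher numbers stand for weaker inhibition and lower numbers for stronger inhibition), compound 1 stands second highest of the three numbers. The step to compound 2 is a 4.1-fold higher number from compound 1 to compound 2 (0.61 log units; beyond the scatter), a modest move towards weaker inhibition. The step to compound 3 is a 14-fold lower number from compound 1 to compound 3 (1.13 log units; beyond the scatter), a large move towards stronger inhibition, and the step between compound 2 and compound 3 is a 56-fold lower number from compound 2 to compound 3 (1.75 log units; beyond the scatter), the largest gap in the set.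

Compound 4 `Fc1ccc(CSc2nnc(-c3ccc4c(c3)OCCO4)n2-c2ccccc2)c(F)c1` has not been measured. Compared with compound 1 it carries 2,4-difluorophenyl in place of 4-nitrophenyl on a saturated chain carbon bound to a sulfur. The step that bears most directly on this change is that from compound 1 to compound 3, where a single fluoro took the place of the nitro and gave a 14-fold lower number from compound 1 to compound 3 (1.13 log units; beyond the scatter). Going by the values given here, compound 4 adds a second fluoro on the same ring, for which no measured step exists. The expectation for compound 4 therefore rests on compound 3 alone: a large step downward, close to an 11-fold lower number from compound 1 to compound 4 (1.03 log units; beyond the scatter), with an estimated value of 1300 nM and a range from 300 nM to 6000 nM.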

Compound 4, half-maximal inhibitory concentration: 1960 nM
Compound 4: the middle estimate sits 1.5-fold (0.18 log units) below what was measured; the measured number falls inside the stated range.
By their numbers in this assay, from the lowest: compounds 3 and 4 (each within the scatter of the next); then compound 1; then compound 2.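

In this assay, the second fluoro on the ring brings no readable change, with a 1.9-fold higher number from compound 3 to compound 4 (0.28 log units; within the scatter) and so no separation of the two fluorinated compounds. The 2,4-difluorophenyl group therefore keeps the standing that the single fluoro held against the other two groups, with a 7.0-fold lower number from compound 1 to compound 4 (0.85 log units; beyond the scatter) against the 4-nitrophenyl group and a 29-fold lower number from compound 2 to compound 4 (1.46 log units; beyond the scatter) against the 4-methylphenyl group. Nothing measured here accounts for the gap between the fluorinated rings and those carrying nitro or methyl.

The compounds shown leave open how an unsubstituted phenyl, a chloro, a methoxy or an amine on the same ring would read. They also leave open whether a longer chain at the saturated chain carbon bound to a sulfur would hold the numbers of the fluorinated compounds.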